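Halogen exchange on the shared core

The source may report more compounds than this note shows. Statements on the series, on what has been measured and on what is new or still open speak of the compounds shown alone.

Compound 2 `O=c1c(-c2nn[nH]n2)c[nH]c2ccc(Cl)cc12` sits at the limit of > 10 mg/kg in this assay, at which 1 of the 3 values shown sits: in a functional assay on the whole organism (strain Sprague-Dawley) for inhibition, with Rattus norvegicus as the target (on this read-out lower numbers stand for an effect already at smaller amounts and higher numbers for an effect only at larger amounts of compound), compound 2 gives > 10 mg/kg, a limit of the assay and not a number. Compound 1 `O=c1c(-c2nn[nH]n2)c[nH]c2ccccc12` gives 1.25 mg/kg in this assay. Compound 3 `COc1ccc2c(O)c(C(=O)O)cnc2c1` also ends at a limit; in this assay compound 3 gives > 50 mg/kg. Compound 4 `O=c1c(-c2nn[nH]n2)c[nH]c2ccc(F)cc12` differs from compound 2 by fluoro in place of chloro on an aromatic carbon. Among the measured compounds shown here, the only measured step that bears on this change is an at least 8.0-fold higher number from compound 1 to compound 2 (0.90 log units; beyond the scatter), so the halogen carries weight here, but no measured pair shows fluoro against chloro. Compound 4 is therefore expected near 5 mg/kg, between 1.5 mg/kg and 20 mg/kg. The expected step of an at least 2.0-fold lower number from compound 2 to compound 4 (0.30 log units; that floor lies within the scatter) starts from a limit and is itself uncertain in size.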

Compound 4, minimum effective dose: 1.25 mg/kg
The estimate for compound 4 lay 4.0-fold (0.60 log units) above the measured number; measured number outside the range, below it.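

At this aromatic position the outcome in this assay turns on which halogen enters: fluoro in place of chloro gives an at least 8.0-fold lower number from compound 2 to compound 4 (0.90 log units; beyond the scatter), while fluoro in place of hydrogen gives no change at the digits printed from compound 1 to compound 4 (within the scatter). The higher number therefore does not go with halogen as such; among the compounds shown on the shared core, it goes with chloro only. Compound 2 stands at a limit of the assay and not a number: the limit of > 10 mg/kg in this assay, at which 1 of the 4 values shown sits.

As far as these compounds go, the full size of the chloro step stays open. Also open, from the compounds shown here alone, is whether bromo or an amine at this position would track compound 4 or compound 2.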